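Branched acyl groups on the shared core: compound 4

The compounds below may be only part of what the source reports. "The series", "measured", "known", "first", "only" and "open" are said of these compounds alone.

Compound 1 `CC(=O)N1CC2CC(C1)N2`: 750 nM
Compound 2 `CCCC(=O)N1CC2CC(C1)N2`: 300 nM
Compound 3 `CC(C)C(=O)N1CC2CC(C1)N2`: 16000 nM

In an assay on CHO cells for agonist activity at Neuronal acetylcholine receptor; alpha3/alpha6/beta2/beta3 (Homo sapiens), read by FLIPR and calcium flux (on this read-out higher numbers stand for an effect only at larger amounts of compound and lower numbers for an effect already at smaller amounts), compound 3 stands highest of the three numbers: a 21-fold higher number from compound 1 to compound 3 (1.33 log units; beyond the scatter) and a 53-fold higher number from compound 2 to compound 3 (1.73 log units; beyond the scatter), both beyond the scatter. Compound 4 `C[C@@H]1C[C@H]1C(=O)N1CC2CC(C1)N2` arises through (2-methylcyclopropyl in place of isopropyl on a carbonyl carbon). Going by the values given here, the steps that bear on this change are the two into compound 3, which show that branching on the carbonyl carbon gave large rises against compound 1 and compound 2; compound 4 keeps a carbon bound to the carbonyl that carries two further carbons, now closed into a three-membered ring. Among the compounds with values here, no measured step covers a ring at this position, so the expected step in this assay is small, a 1.3-fold lower number from compound 3 to compound 4 (0.12 log units; within the scatter), within the scatter. Compound 4 is estimated at 12000 nM, range 3000 nM to 50000 nM.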

Compound 4, half-maximal effective concentration: 51 nM
Beside the measured number, compound 4's estimate is 240-fold (2.37 log units) above it; the measured number lies below the stated range.
By their numbers in this assay, from the lowest: compound 4; then compound 2; then compound 1; then compound 3.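

In this assay, a carbon on the carbonyl carrying two further carbons does not by itself give a high number: 2-methylcyclopropyl in place of isopropyl gives a 310-fold lower number from compound 3 to compound 4 (2.50 log units; beyond the scatter) and reverses the effect of branching. The ring also passes the unbranched acyl groups, with a 5.9-fold lower number from compound 2 to compound 4 (0.77 log units; beyond the scatter) and a 15-fold lower number from compound 1 to compound 4 (1.17 log units; beyond the scatter) as the steps. No measurement shown gives a reason for this reversal.

Open, on these data alone, is whether the gain follows the three-membered ring or its methyl, which plain cyclopropyl would separate. Also open, as far as these compounds go, is how cyclobutyl or the other stereoisomers of 2-methylcyclopropyl would read.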